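Naphthalen-1-yl for 2-methoxyphenyl in the series

The source may report more compounds than this note shows. Statements on the series, on what has been measured and on what is new or still open speak of the compounds shown alone.

- compound 1 `COc1cc(C(C)=O)ccc1OCCCN1CCC(C(c2ccc(F)cc2)c2ccc(F)cc2)CC1`: 1.59 nM
- compound 2 `COc1ccccc1OCCCN1CCC(C(c2ccc(F)cc2)c2ccc(F)cc2)CC1`: 2.51 nM

Among the compounds with values here, in a functional assay (aorta) with Oryctolagus cuniculus as the target (a lower number here means tighter binding, a higher number weaker binding), compound 2 stands at 2.51 nM, within the scatter of compound 1, the only other measured member. Compound 3 `Fc1ccc(C(c2ccc(F)cc2)C2CCN(CCCOc3cccc4ccccc34)CC2)cc1` carries naphthalen-1-yl in place of 2-methoxyphenyl on an oxygen on a saturated carbon. Within the data shown here, the one measured step, a 1.6-fold higher number from compound 1 to compound 2 (0.20 log units; within the scatter), is hydrogen in place of acetyl on an aromatic carbon. Among the measured compounds shown here, it bears only loosely, since no measured step exchanges the 2-methoxyphenyl itself. No shift beyond the scatter is therefore expected in this assay, though the uncertainty is wide. The expected change is a 1.2-fold higher number from compound 2 to compound 3 (0.08 log units; within the scatter). Compound 3 is estimated at 3 nM, with an expected range of 0.8 nM to 12 nM.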

Compound 3, dissociation constant: 5.01 nM
The estimate for compound 3 lay 1.7-fold (0.22 log units) below the measured number; low and high end bracket the measured number.
By their numbers in this assay, from the lowest: compounds 1, 2 and 3 (each within the scatter of the next, the first and the last beyond it).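

In this assay, naphthalen-1-yl on this oxygen stays level with 2-methoxyphenyl, at a 2.0-fold higher number from compound 2 to compound 3 (0.30 log units; within the scatter), so the two aromatic rings of naphthalen-1-yl and the loss of the methoxy oxygen together leave no shift that can be read. Only the wider exchange of 4-acetyl-2-methoxyphenyl for naphthalen-1-yl passes the scatter, a modest step of a 3.2-fold higher number from compound 1 to compound 3 (0.50 log units; beyond the scatter). Nothing available accounts for either step.

Open, as far as these compounds go, is how naphthalen-2-yl or an unsubstituted phenyl on this oxygen would compare. Also open, from the compounds shown here alone, is whether an acetyl on naphthalen-1-yl would change the number.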